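Swapping a hydroxyethyl group for tert-butyl on a shared core

The source may hold more compounds than are shown below. What is called first, only, known or untested is meant among the compounds shown, and "the series" means these compounds.

Of the compounds shown here, three built on one shared core have been tested in a functional assay on HepG2 cells (Homo sapiens) for inhibition, read by MTT assay, with a stated time of 72 h; on this read-out higher numbers stand for weaker inhibition and lower numbers for stronger inhibition. Compound 1 carries a 2-hydroxyethyl group on its five-membered ring (`O=c1cc(Cn2cc(CCO)nn2)c2ccc(O)cc2o1`). In this assay compound 1 gives only a limit of the assay, > 100000 nM. Compound 2 (`CC(O)c1cn(Cc2cc(=O)oc3cc(O)ccc23)nn1`) carries a 1-hydroxyethyl group instead. In this assay compound 2 likewise gives only a limit, > 100000 nM. Compound 3 (`O=c1cc(Cn2cc(CCCCO)nn2)c2ccc(O)cc2o1`) carries a 4-hydroxybutyl group, and in this assay compound 3 gives again only a limit, > 100000 nM. Because all three values sit at the same limit, (the limit of > 100000 nM in this assay, at which 3 of the 3 values shown sit), none of the steps between them can be read: a step that the two limits leave unreadable from compound 1 to compound 2, a step that the two limits leave unreadable from compound 1 to compound 3 and a step that the two limits leave unreadable from compound 2 to compound 3 all stay unreadable.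

Compound 4 (`CC(C)(C)c1cn(Cc2cc(=O)oc3cc(O)ccc23)nn1`) is not yet measured. It differs from compound 2 in one place: tert-butyl in place of 1-hydroxyethyl on an aromatic carbon. Among the measured compounds shown here, no measured step bears on this change, since every value so far is a limit, so no size or direction of step can be drawn from them. The most that can be said is that the three hydroxy-bearing groups all left the compounds at the limit. Compound 4 is therefore expected to stay near that limit as well, with an estimated step of a number no higher from compound 2 to compound 4 (the limit leaves the size open). The estimate for compound 4 in this assay is 100000 nM, within a range from 30000 nM to 300000 nM.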

Compound 4, half-maximal inhibitory concentration: > 100000 nM
Compound 4: a limit, no number (the forecaster's own chance of this, stated with the estimate: 80%); the middle value sits exactly at the limit.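

In this assay compound 4 gives > 100000 nM as a limit of the assay, not a number. Among the compounds shown here, no step between compound 4 and compounds 1, 2 or 3 can be read, because all four compounds sit at the same limit: the limit of > 100000 nM in this assay, at which 4 of the 4 values shown sit. The compounds shown leave open whether changing this group on the shared core alters inhibition at all.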